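Phenyl to 2-Phenylethenyl on a Shared Glycosylated Core

The source may hold more compounds than are shown below. What is called first, only, known or untested is meant among the compounds shown, and "the series" means these compounds.

Three compounds sharing one core were measured in a functional assay on DU-145 cells (Homo sapiens) for cytotoxicity, read by sulforhodamine B assay, with a stated time of 48 h; on this read-out higher numbers stand for weaker inhibition and lower numbers for stronger inhibition. Compound 2 `CC(=O)OC[C@H]1O[C@@H](n2cc(CN3C(=O)/C(=C/c4ccccc4)c4ccccc43)nn2)[C@H](OC(C)=O)[C@@H](OC(C)=O)[C@@H]1OC(C)=O` gives 22800 nM, the lowest of the three numbers. Compound 3 `COc1ccc(/C=C2\C(=O)N(Cc3cn([C@@H]4O[C@H](COC(C)=O)[C@@H](OC(C)=O)[C@H](OC(C)=O)[C@H]4OC(C)=O)nn3)c3ccccc32)cc1OC` gives 24900 nM, which lies within the scatter of compound 2, so the two cannot be ordered. Compound 1 `CC(=O)OC[C@H]1O[C@@H](n2cc(Cn3cc(/C=C4/C(=O)Nc5ccc(F)cc54)c4ccccc43)nn2)[C@H](OC(C)=O)[C@@H](OC(C)=O)[C@@H]1OC(C)=O` gives 87400 nM, a number beyond the scatter above compound 2.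

Compound 4 `CC(=O)OC[C@H]1O[C@@H](n2cc(CN3C(=O)/C(=C/C=C/c4ccccc4)c4ccccc43)nn2)[C@H](OC(C)=O)[C@@H](OC(C)=O)[C@@H]1OC(C)=O` differs from compound 2 in one place: 2-phenylethenyl in place of phenyl on a double-bonded chain carbon bound to a double-bonded ring carbon. Among the compounds with values here, no pair of measured compounds differing in a single place is available, so there is no measured step to lean on. The change retains the single aromatic ring and adds a double bond outside aromatic rings; the account expects at most a modest shift, most likely none beyond the scatter, with a slight lean toward a lower number. In this assay the expected step is a 1.3-fold lower number from compound 2 to compound 4 (0.10 log units; within the scatter). Compound 4 is estimated at 18000 nM, with a range from 6000 nM to 60000 nM.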

Compound 4, half-maximal inhibitory concentration: 17100 nM
For compound 4 the middle estimate is 1.1-fold (0.02 log units) above the measured one; the measured number falls inside the stated range.
By their numbers in this assay, from the lowest: compounds 4, 2 and 3 (each within the scatter of the next); then compound 1.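

In this assay, within the data shown here, this is the first step across a single place: 2-phenylethenyl in place of phenyl on a double-bonded chain carbon bound to a double-bonded ring carbon gives a 1.3-fold lower number from compound 2 to compound 4 (0.12 log units; within the scatter) and so sets no order between the two compounds. At this position, then, adding a double bond outside aromatic rings while keeping the single aromatic ring produces no change that can be told from the scatter. Nothing shown here offers an explanation for this result.

The compounds shown leave open how this position would respond if the aromatic ring gave way to an amine, a carboxylic acid or a longer chain. They also leave open whether the same change would read alike on the core of compound 1.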